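From fluoro to chloro on a shared core

This account rests on a few compounds, and the source may have more. Where it says the series, first, only, none or still open, it means among the compounds named here.

Compound 1 `O=Cc1cn(Cc2ccc(Cl)cc2)c2ccc(Cl)cc12`: 400 nM
Compound 2 `OCc1cn(Cc2ccc(Cl)cc2)c2ccc(F)cc12`: 30 nM

In a functional assay on NCI-H460 cells (Homo sapiens) for cytotoxicity, read by sulforhodamine B assay, with a stated time of 3 days (on this read-out lower numbers stand for stronger inhibition and higher numbers for weaker inhibition), compound 2 holds the lower of the two numbers, and the gap up to compound 1 lies beyond the usual scatter of repeated measurements. The next compound to be measured, compound 3 `OCc1cn(Cc2ccc(Cl)cc2)c2ccc(Cl)cc12`, departs from compound 2 in one place: chloro in place of fluoro on an aromatic carbon. The exchange sits on a six-membered aromatic ring of carbon only, part of a fused system of two rings. The two measured compounds differ from each other in more than one place, so the data hold no direct measure of this exchange. In this assay a small step is expected, none beyond the scatter, and if any shift appears it should be toward a higher number. The expectation takes compound 2 at 30 nM as its reference. For compound 3 the expected value is 40 nM, with an estimated range from 12 nM to 140 nM as the likely span. The expected 1.3-fold higher number from compound 2 to compound 3 (0.12 log units; within the scatter) stays within the scatter of repeats.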

Compound 3, half-maximal inhibitory concentration: 5750 nM
Beside the measured number, compound 3's estimate is 140-fold (2.16 log units) below it; measured number outside the range, above it.
By their numbers in this assay, from the lowest: compound 2; then compound 1; then compound 3.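

In this assay, the exchange of fluoro for chloro on the aromatic carbon now has a direct measure, and a 190-fold higher number from compound 2 to compound 3 (2.28 log units; beyond the scatter) shows that this position of the shared core is far from indifferent to which halogen it carries, even though the two groups count the same single heavy atom and neither has a hydrogen-bond donor or acceptor. With chloro held fixed, the second exchange, hydroxymethyl in place of formyl on an aromatic carbon, also moves the number well beyond the scatter, as a 14-fold higher number from compound 1 to compound 3 (1.16 log units; beyond the scatter) shows, so hydroxymethyl does not go with the lower number on this chloro-bearing core, and each of the two single changes away from compound 3 gives a lower number. Going by these compounds alone, nothing at hand offers an explanation for why either exchange moves the number so far.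

Going by these compounds, how formyl reads with fluoro on the ring remains open, so it cannot yet be said whether the effect of one exchange depends on the other. Also open, on these data alone, is how bromo or methoxy would read at the halogen position, or how an amine or a carboxylic acid would read in place of hydroxymethyl.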